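Adding a second carboxy group to compound 3

The source may report more compounds than this note shows. Statements on the series, on what has been measured and on what is new or still open speak of the compounds shown alone.

In a functional assay on PC-3 cells (Homo sapiens) for antiproliferative activity, read by MTT assay, with a stated time of 24 h (a higher number here means a weaker inhibitor, a lower number a stronger inhibitor), compound 1 (`CCN(CC)CCNC(=O)c1ccc(C(CC)(CC)c2ccc(OCS(=O)(=O)c3ccccc3)c(C)c2)n1CC`) gives 7130 nM and compound 2 (`CCn1c(C(=O)N[C@H](CO)C(C)C)ccc1C(CC)(CC)c1ccc(OCS(=O)(=O)c2ccccc2)c(C)c1`) gives 7300 nM on the same core, a pair that sits within the scatter (a 1.0-fold higher number from compound 1 to compound 2 (0.01 log units; within the scatter)). Compound 3 (`CCn1c(C(=O)N[C@H](C)C(=O)O)ccc1C(CC)(CC)c1ccc(OCS(=O)(=O)c2ccccc2)c(C)c1`), which carries 1-carboxyethyl on the amide-type nitrogen, gives 20100 nM as the highest number of the three, which makes it the weakest inhibitor here.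

Compound 4 (`CCn1c(C(=O)N[C@@H](CC(=O)O)C(=O)O)ccc1C(CC)(CC)c1ccc(OCS(=O)(=O)c2ccccc2)c(C)c1`) has 1,2-dicarboxyethyl in place of that group (1,2-dicarboxyethyl in place of 1-carboxyethyl on an amide-type nitrogen). Going by the values given here, the closest evidence is the arrival of the single carboxy group, seen in two modest upward steps (a 2.8-fold higher number from compound 1 to compound 3 (0.45 log units; beyond the scatter); a 2.8-fold higher number from compound 2 to compound 3 (0.44 log units; beyond the scatter)). Among the compounds with values here, no measured compound yet carries two such groups, so this is a thin basis. On those steps, a further rise no larger than they were seems likely, and it may stay within the scatter. The estimated change in this assay is a small upward one (a 1.7-fold higher number from compound 3 to compound 4 (0.23 log units; within the scatter)). Compound 4 is therefore estimated at 34000 nM (expected range 14000 nM to 85000 nM).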

Compound 4, half-maximal inhibitory concentration: > 50000 nM
Compound 4: no number, only a limit; the forecaster's own chance of this, stated with the estimate: 20%; middle value at least 1.4-fold (0.16 log units) from the limit.
By their numbers in this assay, from the lowest: compounds 1 and 2 (each within the scatter of the next); then compound 3. At a limit, above all of these: compound 4.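

In this assay compound 4 gives > 50000 nM as a limit of the assay and not a number. The steps into it therefore give only the smallest possible change, and all three lie beyond the scatter (an at least 2.4-fold higher number from compound 3 to compound 4 (0.39 log units; beyond the scatter); an at least 6.8-fold higher number from compound 2 to compound 4 (0.83 log units; beyond the scatter); an at least 7.0-fold higher number from compound 1 to compound 4 (0.84 log units; beyond the scatter)). The earlier compounds shown here showed only what one carboxy group does on the amide-type nitrogen, whereas compound 4 shows that going from 1-carboxyethyl to 1,2-dicarboxyethyl pushes the number up further, making compound 4 the weakest inhibitor of the four.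

This change adds a second carboxy group and lengthens the chain at once, so a methyl ester or a primary amide at that spot would be needed to tell the two apart. Going by these compounds, how far the true value of compound 4 lies past its limit also stays open.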